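The source may report more compounds than this note shows. Statements on the series, on what has been measured and on what is new or still open speak of the compounds shown alone.

In a functional assay on HeLa cells (Homo sapiens) for antiproliferative activity, read by MTT assay, with a stated time of 72 h (on this read-out lower numbers stand for stronger inhibition and higher numbers for weaker inhibition), three compounds have been measured. Compound 1 `O=c1c(Cl)c(CSC(=S)N2CCCCC2)oc2ccccc12` gives 9800 nM. Compound 2 `O=c1c(CSC(=S)N2CCOCC2)coc2cc(Cl)ccc12` gives 2000 nM, and compound 3 `O=c1cc(CSC(=S)N2CCOCC2)oc2cc(Cl)ccc12` gives 33300 nM. Among these three numbers compound 2 stands lowest; its nearest neighbour is compound 1, whose number is higher by a step beyond the scatter, and compound 3 lies furthest from it, higher by a still wider step. The three compounds differ from one another in more than one place at once, so no single change can be read off from the measured pairs.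

Compound 4 `O=c1c(CSC(=S)N2CCCC2)coc2cc(Cl)ccc12` has not yet been measured in this assay. It differs from compound 2 in one place: pyrrolidin-1-yl in place of morpholin-4-yl on a thiocarbonyl carbon. For the measured compounds named here, no measured pair shows the effect of such a swap on its own, so the direction is open. The step from compound 2 to compound 4 is expected to be small, a 1.3-fold lower number from compound 2 to compound 4 (0.10 log units; within the scatter), and is not expected to reach beyond the usual scatter. On that basis compound 4 is estimated to give 1600 nM in this assay, within a range from 400 nM to 6500 nM.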

Compound 4, half-maximal inhibitory concentration: 1300 nM
Beside the measured number, compound 4's estimate is 1.2-fold (0.09 log units) above it; the range from low to high includes it.
By their numbers in this assay, from the lowest: compounds 4 and 2 (each within the scatter of the next); then compound 1; then compound 3.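

In this assay, for the compounds shown here, the first pair that differs in one place gives a 1.5-fold lower number from compound 2 to compound 4 (0.19 log units; within the scatter), so pyrrolidin-1-yl in place of morpholin-4-yl on a thiocarbonyl carbon leaves the number within the usual scatter. On the core shared by compound 2 and compound 4, the oxygen of morpholin-4-yl and the larger ring can therefore be given up without a step beyond that scatter. Nothing available explains this result or bears on it.

On these data alone, compound 1 carries piperidin-1-yl, but it differs from compound 2 in more than one place, so how piperidin-1-yl behaves on the core of compound 2 stays open. Also open, as far as these compounds go, is whether an open-chain diethylamino group or a piperazin-1-yl ring with a free amine at this place would move the number beyond the scatter.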